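Thiophene analogue compound 2 and its methylated successor

A few compounds are considered here, and "the series" means these few. Any claim that something is new, unique, unknown or untested is made for them only; others in the source may bear on it.

Compound 1 `COc1ccc(OC)c(C(=O)/C=C/c2ccoc2)c1` gives 12000 nM
Compound 2 `COc1ccc(OC)c(C(=O)/C=C/c2ccsc2)c1` gives 5700 nM
Compound 3 `COc1ccc(OC)c(C(=O)/C=C/c2ccc(C)o2)c1` gives 26500 nM

In a functional assay on Hep 3B2 cells (Homo sapiens) for cytotoxicity, read by MTT assay (a higher number here means a weaker inhibitor, a lower number a stronger inhibitor), compound 2 has the lowest number of the three. Compound 4 `COc1ccc(OC)c(C(=O)/C=C/c2sccc2C)c1` differs from it by 3-methylthiophen-2-yl in place of thiophen-3-yl on a double-bonded chain carbon bound to a double-bonded chain carbon. Among the compounds with values here, no measured step makes this exact change. The nearest evidence is the pair of steps that bring in the methylated 5-methylfuran-2-yl: a 2.2-fold higher number from compound 1 to compound 3 (0.34 log units; beyond the scatter) and a 4.6-fold higher number from compound 2 to compound 3 (0.67 log units; beyond the scatter). Only compound 3 carries a methyl, so the methyl cannot be separated from the change of ring. A modest rise is therefore expected, with a 1.7-fold higher number from compound 2 to compound 4 (0.22 log units; within the scatter) as the estimated step. The estimate for compound 4 is 9500 nM, with an expected range of 3500 nM to 25000 nM.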

Compound 4, half-maximal inhibitory concentration: 16700 nM
The estimate for compound 4 lay 1.8-fold (0.24 log units) below the measured number, and the stated range covers the measured number.
By their numbers in this assay, from the lowest: compound 2; then compounds 1, 4 and 3 (each within the scatter of the next, the first and the last beyond it).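

In this assay the change to 3-methylthiophen-2-yl gives a 2.9-fold higher number from compound 2 to compound 4 (0.47 log units; beyond the scatter) and so shows that a thiophene ring at this place does not by itself keep the number of compound 2. The steps of a 1.6-fold lower number from compound 3 to compound 4 (0.20 log units; within the scatter) and a 1.4-fold higher number from compound 1 to compound 4 (0.14 log units; within the scatter) both stay within the scatter, so compound 4 is not separated from either furan compound. No measurement at hand explains these steps.

This step joins a methyl to a change from thiophen-3-yl to a thiophen-2-yl, and the compounds shown cannot part the two. As far as these compounds go, how unmethylated thiophen-2-yl, or an amine on this ring, would read remains open.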